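Trimethoxyphenyl to nitrophenyl swap in the sulfonamide series

The source may hold more compounds than are shown below. What is called first, only, known or untested is meant among the compounds shown, and "the series" means these compounds.

Measured in a functional assay on QGY-7703 cells (Homo sapiens) for cytotoxicity, read by MTT assay, with a stated time of 24 h; on this read-out lower numbers stand for stronger inhibition and higher numbers for weaker inhibition:
- compound 1 `CC(=O)Nc1ccc(S(=O)(=O)N2C/C(=C\c3ccc(C#N)cc3)C(=O)/C(=C/c3ccc(C#N)cc3)C2)cc1`: 3320 nM
- compound 2 `COc1cc(/C=C2\CN(S(=O)(=O)c3ccc(NC(C)=O)cc3)C/C(=C\c3cc(OC)c(OC)c(OC)c3)C2=O)cc(OC)c1OC`: 1900 nM
- compound 3 `O=C1/C(=C/c2cccc([N+](=O)[O-])c2)CN(S(=O)(=O)c2ccc(F)cc2)C/C1=C\c1ccccc1F`: 14900 nM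

Compound 2, at 1900 nM, lies within the scatter of compound 1, while compound 3 stands beyond the scatter with a higher number. Compound 4 `COc1cc(/C=C2\CN(S(=O)(=O)c3ccc(NC(C)=O)cc3)C/C(=C\c3cccc([N+](=O)[O-])c3)C2=O)cc(OC)c1OC` carries 3-nitrophenyl in place of 3,4,5-trimethoxyphenyl on a double-bonded chain carbon bound to a double-bonded ring carbon. For the measured compounds named here, no measured pair isolates this change. Going by the values given here, the only guide is compound 3, which also bears 3-nitrophenyl and gives 14900 nM, but it differs elsewhere too. A modest rise in the number is therefore expected in this assay, with the expected step being a 1.8-fold higher number from compound 2 to compound 4 (0.27 log units; within the scatter). For compound 4 the estimated value is 3500 nM, with an expected range of 1500 nM to 9000 nM.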

Compound 4, half-maximal inhibitory concentration: 2550 nM
Compound 4: the middle estimate sits 1.4-fold (0.14 log units) above what was measured, and the stated range covers the measured number.
By their numbers in this assay, from the lowest: compounds 2, 4 and 1 (each within the scatter of the next); then compound 3.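

In this assay, replacing 3,4,5-trimethoxyphenyl with 3-nitrophenyl on a double-bonded chain carbon bound to a double-bonded ring carbon gives a 1.3-fold higher number from compound 2 to compound 4 (0.13 log units; within the scatter). For the compounds shown here, this is the first comparison that isolates a single place, and it shows that this exchange on one of the two arms does not carry the number beyond the scatter. No supporting measurement offers an explanation for this result. Still open, on these data alone, is whether an amine or a carboxylic acid at this place would also stay within the scatter. Also open, as far as these compounds go, is what exchanging the remaining 3,4,5-trimethoxyphenyl group would do.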